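Ring Size at the Thiocarbonyl Shapes Antiproliferative Potency

The source may report more compounds than this note shows. Statements on the series, on what has been measured and on what is new or still open speak of the compounds shown alone.

Measured compounds:
compound 1 `Cc1ccc2c(=O)c(CSC(=S)N3CCCCC3)coc2c1` with 800 nM
compound 2 `Cc1ccc2c(=O)c(CSC(=S)N3CCCC3)coc2c1` with 41400 nM
compound 3 `O=c1c(CSC(=S)N2CCCCC2)coc2cc(Cl)ccc12` with 380 nM

Three compounds were tested in a functional assay on MCF7 cells (Homo sapiens) for antiproliferative activity, read by MTT assay, with a stated time of 72 h; on this read-out higher numbers stand for weaker inhibition and lower numbers for stronger inhibition. Compound 1 gives 800 nM. Compound 2 differs from it by pyrrolidin-1-yl in place of piperidin-1-yl on a thiocarbonyl carbon and gives 41400 nM, a step of a 52-fold higher number from compound 1 to compound 2 (1.71 log units; beyond the scatter). Compound 3 differs from compound 1 by chloro in place of methyl on an aromatic carbon. In this assay compound 3 gives 380 nM, a step of a 2.1-fold lower number from compound 1 to compound 3 (0.32 log units; beyond the scatter), which makes compound 3 the most potent of the three measured compounds in this assay.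

Compound 4 `O=c1c(CSC(=S)N2CCCC2)coc2cc(Cl)ccc12` has not been measured. It differs from compound 3 by pyrrolidin-1-yl in place of piperidin-1-yl on a thiocarbonyl carbon, the same change that takes compound 1 to compound 2. The core of compound 3 differs from that of compound 1 by chloro in place of methyl on an aromatic carbon. The place of the change is the same in both pairs, a thiocarbonyl carbon whose other neighbour is sulfur.

For the measured compounds named here, on the one precedent available, the change made the large step of a 52-fold higher number from compound 1 to compound 2 (1.71 log units; beyond the scatter). The expectation for compound 4 in this assay rests on that single step applied to compound 3, whose value is 380 nM; a step of similar size is expected, a 53-fold higher number from compound 3 to compound 4 (1.72 log units; beyond the scatter). Going by the values given here, with only one earlier example, the width of the expectation is kept broad. Compound 4 is therefore estimated at 20000 nM, with a range from 4000 nM to 80000 nM.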

Compound 4, half-maximal inhibitory concentration: 600 nM
Compound 4: middle estimate off by 33-fold (1.52 log units), on the high side; measured number below the stated range.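

In this assay, pyrrolidin-1-yl in place of piperidin-1-yl on a thiocarbonyl carbon gave a 1.6-fold higher number from compound 3 to compound 4 (0.20 log units; within the scatter) on the chloro-bearing core, so the large loss seen on the methyl-bearing core did not carry over: the same change on two cores in this assay, a 52-fold higher number (1.71 log units; beyond the scatter) from compound 1 to compound 2 and a 1.6-fold higher number (0.20 log units; within the scatter) from compound 3 to compound 4, 33-fold (1.52 log units) apart, beyond the scatter of two such steps

Read the other way, chloro in place of methyl on an aromatic carbon gave a 69-fold lower number from compound 2 to compound 4 (1.84 log units; beyond the scatter), and this step too differs from its counterpart on the piperidin-1-yl compounds: the same change on two cores in this assay, a 2.1-fold lower number (0.32 log units; beyond the scatter) from compound 1 to compound 3 and a 69-fold lower number (1.84 log units; beyond the scatter) from compound 2 to compound 4, 33-fold (1.52 log units) apart, beyond the scatter of two such steps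

Across these four compounds, the size of each change therefore depends on what stands at the other place, so neither step can be moved to another core as a fixed amount, although this single set of four does not show why the two changes interact or whether compound 2 is an isolated case.

On these data alone, it remains open whether a morpholin-4-yl or a diethylamino group on the thiocarbonyl carbon would behave like the pair of compound 3 and compound 4 or show a sharp dependence on the core like the pair of compound 1 and compound 2. As far as these compounds go, it is equally open how the step from piperidin-1-yl to pyrrolidin-1-yl would turn out on cores carrying fluoro or methoxy in place of chloro or methyl.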